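From Benzamidomethyl to Amino on the Side Chain

This account rests on a few compounds, and the source may have more. Where it says the series, first, only, none or still open, it means among the compounds named here.

Compound 1 `Nc1cccc(Nc2c(C(=O)NCc3ccc(F)cc3)nc(Br)c3cccnc23)c1`, compound 2 `O=C(NCc1ccc(F)cc1)c1nc(Br)c2cccnc2c1NCCO` and compound 3 `O=C(NCCCNc1c(C(=O)NCc2ccc(F)cc2)nc(Br)c2cccnc12)c1ccccc1` share one core and differ in the group on a nitrogen on an aromatic ring. In a functional assay on HCT-116 cells (Homo sapiens) for cytotoxicity, read by MTT assay, with a stated time of 72 h (a higher number here means a weaker inhibitor, a lower number a stronger inhibitor), compound 1 gives > 10000 nM, which is a limit. Compound 2 gives > 20000 nM, also a limit. Compound 3 gives > 10000 nM, again a limit, so no exact number places it. Compound 4 `NCCNc1c(C(=O)NCc2ccc(F)cc2)nc(Br)c2cccnc12` has amino in place of benzamidomethyl on a saturated chain carbon, two bonds along the chain from a nitrogen on an aromatic ring. The measured changes are a step that the two limits leave unreadable from compound 1 to compound 2 and a step that the two limits leave unreadable from compound 2 to compound 3, so neither offers a size to carry over. The expected change in this assay is a step that the limit leaves unreadable from compound 3 to compound 4, with no firm direction. Compound 4 is estimated at 12000 nM, within an expected range of 3000 nM to 30000 nM.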

Compound 4, half-maximal inhibitory concentration: > 20000 nM
Compound 4 ended at the assay's limit; the forecaster's own chance of this, stated with the estimate: 60%; at least 1.6-fold (0.22 log units) between middle value and limit.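

Going by these compounds alone, compound 4 gives > 20000 nM, a limit, so no step to compound 4 from compound 1, compound 2 or compound 3 can be read. The compounds shown leave open whether any group on this nitrogen changes cytotoxicity, as none has an exact value.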